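Benzoyl to carboxy: what compound 4 may lose

The compounds below may be only part of what the source reports. "The series", "measured", "known", "first", "only" and "open" are said of these compounds alone.

Measured in a functional assay on SEM cells (Homo sapiens) for cytotoxicity, with a stated time of 72 h; on this read-out lower numbers stand for an effect already at smaller amounts and higher numbers for an effect only at larger amounts of compound:
Compound 1 `C=C[C@@](C)(/C=C/c1ccc(O)cc1)CCC(O)C(C)(C)O`: > 36600 nM, a limit
Compound 2 `C=C[C@@](C)(/C=C/c1ccc(O)cc1)CC/C=C(\C)CO`: > 36600 nM, a limit
Compound 3 `C=C[C@@](C)(/C=C/c1ccc(O)c(/C=C/C(=O)c2ccccc2)c1)CCC=C(C)C`: 8000 nM

Going by the values given here, compound 3 gives the only true number of the three, 8000 nM. The other two entries are limits. The unmeasured compound 4 `C=C[C@@](C)(/C=C/c1ccc(O)c(/C=C/C(=O)O)c1)CCC=C(C)C` keeps the rest of compound 3 and changes one group: hydroxy in place of phenyl on a carbonyl carbon. In words, hydroxy stands in place of phenyl on a carbonyl carbon, which reads as benzoyl to carboxy.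

Among the compounds with values here, the one measured step, a step that the two limits leave unreadable from compound 1 to compound 2, offers little guidance, as it lies elsewhere in the structure and has no readable size. The closer guide is the limit of > 36600 nM in this assay, at which 2 of the 3 values shown sit. Neither compound 1 nor compound 2 carries a benzoyl group, and neither gives a number in this assay. Within the data shown here, compound 4 also lacks benzoyl, although no carboxy compound has been measured, so this rests on very thin evidence. A shift towards weaker effect is therefore expected, and a reading at the limit is quite possible. The expected change is a 3.5-fold higher number from compound 3 to compound 4 (0.54 log units; beyond the scatter), towards larger amounts. For compound 4 the estimated value is 28000 nM, with an expected range of 12000 nM to 60000 nM.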

Compound 4, half-maximal effective concentration: > 36600 nM
Compound 4 was reported as a limit; the forecaster's own chance of this, stated with the estimate: 55%; middle value at least 1.3-fold (0.11 log units) away from the limit.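

In this assay, the change on the carbonyl carbon from benzoyl to carboxy is an at least 4.5-fold higher number from compound 3 to compound 4 (0.66 log units; beyond the scatter). Going by these compounds alone, this is the first readable step at this place: the earlier compounds gave a single true number here, and the one earlier step lay elsewhere in the structure and could not be read. Compound 4 is reported only as a limit, so the step has a lower bound and no full size, and compound 3 alone keeps a true number among the compounds shown: the limit of > 36600 nM in this assay, at which 3 of the 4 values shown sit.

The compounds shown leave open whether the phenyl group itself matters on this carbonyl carbon or whether another group would keep the effect of compound 3, such as a methyl, a methoxy, an amine or a substituted phenyl. They also leave open how far past its limit compound 4 lies, and so whether hydroxy in place of phenyl brings a modest change or a much larger one.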